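Replacing azido with hydroxy on the benzyl group

A few compounds are considered here, and "the series" means these few. Any claim that something is new, unique, unknown or untested is made for them only; others in the source may bear on it.

In a functional assay on MGC-803 cells (Homo sapiens) for inhibition, read by CCK-8 assay, with a stated time of 48 h (a higher number here means a weaker inhibitor, a lower number a stronger inhibitor), compound 1 `COc1ccc(CN(C(=O)CSC(=S)N2CCN(C(=O)OC(C)(C)C)CC2)c2cc(OC)c(OC)c(OC)c2)cc1C` reaches only a limit of the assay, > 20000 nM. For the measured compounds named here, compound 2 `COc1ccc(CN(C(=O)CSC(=S)N2CCN(C(=O)OC(C)(C)C)CC2)c2cc(OC)c(OC)c(OC)c2)cc1N=[N+]=[N-]` gives 810 nM, the only true number so far. The step between them is an at least 24-fold lower number from compound 1 to compound 2 (1.39 log units; beyond the scatter), and its size is bounded on one side by the limit of > 20000 nM in this assay, at which 1 of the 2 values shown sits.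

Compound 3 `COc1ccc(CN(C(=O)CSC(=S)N2CCN(C(=O)OC(C)(C)C)CC2)c2cc(OC)c(OC)c(OC)c2)cc1O` carries hydroxy in place of azido on an aromatic carbon, ortho to a methoxy group (hydroxy in place of azido on an aromatic carbon). The change turns 3-azido-4-methoxybenzyl into 3-hydroxy-4-methoxybenzyl.

Going by the values given here, only one measured step bears on this position, an at least 24-fold lower number from compound 1 to compound 2 (1.39 log units; beyond the scatter), and it shows that this assay responds strongly to the group placed there. Among the compounds with values here, no hydroxy example has been measured, so the direction is a judgement: a moderately lower number is expected, and a higher one is not excluded. The expected size of the change is a step of a 3.2-fold lower number from compound 2 to compound 3 (0.51 log units; beyond the scatter). For compound 3 the estimate is 250 nM, with an expected range of 25 nM to 3000 nM.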

Compound 3, half-maximal inhibitory concentration: 82 nM
Beside the measured number, compound 3's estimate is 3.0-fold (0.48 log units) above it; measured number inside the range.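

Hydroxy gives the lowest number seen at this position so far, and the step of a 9.9-fold lower number from compound 2 to compound 3 (0.99 log units; beyond the scatter) shows that azido, until now the only group here with a true number, is not the limit of what the position allows in this assay. The three groups now fall into one order, from methyl through azido to hydroxy, with every step between them beyond the scatter, and the smallest group of the three gives the lowest number. From methyl to hydroxy the step is an at least 240-fold lower number from compound 1 to compound 3 (2.38 log units; beyond the scatter), and its size is only a bound: the limit of > 20000 nM in this assay, at which 1 of the 3 values shown sits.

Hydroxy brings a hydrogen-bond donor where azido has none, and these compounds cannot tell whether that donor or some other difference between the groups goes with the step; a methoxy group or an amine at the same aromatic carbon would bear on that question. Going by these compounds, it also stays open whether the order of the three groups holds when the tert-butyl carbamate on the piperazine side of the core is replaced by a different group, such as a carboxylic acid.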